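The compounds below may be only part of what the source reports. "The series", "measured", "known", "first", "only" and "open" are said of these compounds alone.

Compound 1 `O=c1ccoc2cc(OCc3cn(Cc4ccccc4)nn3)ccc12` and compound 2 `Cc1ccccc1Cn1cc(COc2ccc3c(=O)ccoc3c2)nn1` share one core and differ in a single place. In an ADME assay on L02 cells (Homo sapiens) for cytotoxicity, read by MTT assay, with a stated time of 48 h (on this read-out higher numbers stand for weaker inhibition and lower numbers for stronger inhibition), compound 1 gives > 300000 nM, which is a limit of the assay rather than a number. In this assay compound 2 gives > 300000 nM, again a limit and not a measured number. The step that the two limits leave unreadable from compound 1 to compound 2 therefore has no readable size, since the limit of > 300000 nM in this assay, at which 2 of the 2 values shown sit, shows both values resting at the same edge of the tested range. This is where compound 2 stands: no cytotoxic effect strong enough to be measured within that range.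

Compound 3 `O=c1ccoc2cc(OCc3cn(Cc4cccc([N+](=O)[O-])c4)nn3)ccc12` differs from compound 2 in one place: 3-nitrophenyl in place of 2-methylphenyl on a saturated chain carbon bound to an aromatic nitrogen. No measured step bears on this change; the single step shown is unreadable, and it concerns a different group. With both neighbours sitting at the limit, no direction can be read from the data, so no movement beyond the scatter is expected. The estimate for compound 3 in this assay is therefore 300000 nM, with a range from 60000 nM to 1500000 nM. The step expected from compound 2 to compound 3 is a number no higher from compound 2 to compound 3 (the limit leaves the size open).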

Compound 3, half-maximal inhibitory concentration: > 300000 nM
Compound 3: only a limit was reported; the forecaster's own chance of this, stated with the estimate: 60%; the middle value sits exactly at the limit.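

In this assay compound 3 gives > 300000 nM, again a limit and not a number. No new step can be read among compound 1, compound 2 and compound 3, as all three values rest at the same limit: the limit of > 300000 nM in this assay, at which 3 of the 3 values shown sit. The compounds shown leave open whether the methyl, nitro or 3-nitrophenyl changes affect this read-out at all.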